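The compounds below may be only part of what the source reports. "The series", "measured", "known", "first", "only" and "open" are said of these compounds alone.

Three amides sharing one core have numbers in a functional assay on MDA-MB-231 cells (Homo sapiens) for antiproliferative activity, read by CCK-8 assay, with a stated time of 72 h; a lower number here means a stronger inhibitor, a higher number a weaker inhibitor. Compound 1 `Cc1ccc(C(=O)Nc2cccc(-c3oc4cc(-c5ccc(F)cc5)ccc4c(=O)c3O)c2)cc1` gives 4350 nM. Compound 2 `O=C(Nc1cccc(-c2oc3cc(-c4ccc(F)cc4)ccc3c(=O)c2O)c1)c1ccc(F)cc1F` gives 11200 nM. Compound 3 `COc1ccccc1C(=O)Nc1cccc(-c2oc3cc(-c4ccc(F)cc4)ccc3c(=O)c2O)c1` gives 5110 nM, which stands second highest of the three: next to compound 1, the gap being a 1.2-fold higher number from compound 1 to compound 3 (0.07 log units; within the scatter), and apart from compound 2, with a 2.2-fold lower number from compound 2 to compound 3 (0.34 log units; beyond the scatter).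

The next compound, compound 4 `O=C(Nc1cccc(-c2oc3cc(-c4ccc(F)cc4)ccc3c(=O)c2O)c1)c1cc(F)cc(F)c1`, differs from compound 3 by 3,5-difluorophenyl in place of 2-methoxyphenyl on a carbonyl carbon.

Within the data shown here, two measured steps bear on this. Exchanging 4-methylphenyl for 2,4-difluorophenyl brought a 2.6-fold higher number from compound 1 to compound 2 (0.41 log units; beyond the scatter), and exchanging 2,4-difluorophenyl for 2-methoxyphenyl brought a 2.2-fold lower number from compound 2 to compound 3 (0.34 log units; beyond the scatter); a difluorophenyl on the carbonyl carbon thus went with the highest of the three numbers. The 3,5-difluorophenyl of compound 4 is not the same group as that in compound 2, so only a modest upward step in this assay is expected, roughly a 1.6-fold higher number from compound 3 to compound 4 (0.19 log units; within the scatter), with a real chance of no step beyond the scatter.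

For compound 4 the expected value in this assay is 8000 nM, within the range 3500 nM to 18000 nM.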

Compound 4, half-maximal inhibitory concentration: 2440 nM
Compound 4: the middle estimate sits 3.3-fold (0.52 log units) above what was measured; the whole stated range lies above it.
By their numbers in this assay, from the lowest: compounds 4, 1 and 3 (each within the scatter of the next, the first and the last beyond it); then compound 2.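

In this assay, the two difluorophenyl amides do not behave alike, with a 4.6-fold lower number from compound 2 to compound 4 (0.66 log units; beyond the scatter); at this position on the carbonyl carbon, a difluorophenyl group as such therefore does not go with a high number, and the arrangement of the two fluorines matters. The 3,5-difluorophenyl group also improves on 2-methoxyphenyl, with a 2.1-fold lower number from compound 3 to compound 4 (0.32 log units; beyond the scatter), whereas a 1.8-fold lower number from compound 1 to compound 4 (0.25 log units; within the scatter) leaves the 3,5-difluorophenyl and 4-methylphenyl amides unseparated. No evidence is at hand to explain these steps.

Every amide shown carries a substituted phenyl on the carbonyl carbon, so it remains open how a cyclohexyl, a pyridyl or a phenyl bearing a carboxylic acid would compare. Going by these compounds, whether the steps hold beyond this assay also remains open.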